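This account rests on a few compounds, and the source may have more. Where it says the series, first, only, none or still open, it means among the compounds named here.

Compound 1 `COc1ccc(F)cc1CNCCCNc1ccnc2cc(Cc3ccc(F)cc3Cl)ccc12` gives 9.47 in a physicochemical assay for acid dissociation, level with compound 2 `Fc1ccc(Cc2ccc3c(NCCCNCc4ccco4)ccnc3c2)c(Cl)c1` at 9.47 and with compound 3 `COc1cccc(CNCCCNc2ccnc3cc(CCc4ccccc4)ccc23)c1O` at 9.47. Going by the values given here, the one measured step between single-point changes, no change at the digits printed from compound 1 to compound 2 (within the scatter), shows nothing beyond the scatter, and it concerns a group on a saturated chain carbon bound to an amine nitrogen. Compound 4 `COc1ccc(F)cc1CNCCCNc1ccnc2cc(-c3ccccc3)ccc12` differs from compound 1 elsewhere: phenyl in place of 2-chloro-4-fluorobenzyl on an aromatic carbon. Among the compounds with values here, the saturated chain and its amine nitrogens are unchanged in compound 4, and no measured step bears directly on an exchange at this aromatic carbon. Compound 4 is therefore expected to show no change at the digits printed from compound 1 to compound 4 (within the scatter), no step beyond the scatter. Compound 4 is estimated at 9.47, with a range from 9.1 to 9.85.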

Compound 4, acid dissociation constant: 9.47
Compound 4: the middle estimate sits on the measured number at the digits printed; the range from low to high includes it.
By their numbers in this assay, from the lowest: compounds 1, 2, 3 and 4 (each within the scatter of the next).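

In this assay, the exchange at this aromatic carbon gives no change at the digits printed from compound 1 to compound 4 (within the scatter), so the read-out extends beyond the saturated chain change seen earlier. Phenyl carries neither the chlorine nor the fluorine of 2-chloro-4-fluorobenzyl, and the step still stays within the scatter. No measurement at hand explains this result.

From the compounds shown here alone, whether an amine or a carboxylic acid on this aromatic carbon would leave the read-out level remains open. A longer chain in place of the saturated chain carrying the amine nitrogens also remains untested in the compounds shown.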